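Ring Size at the Chain End in a Cytotoxicity Series

A few compounds are considered here, and "the series" means these few. Any claim that something is new, unique, unknown or untested is made for them only; others in the source may bear on it.

Three measured compounds share a large core and differ at its far end, where a saturated chain carries a small ring. Among the compounds with values here, compound 1 `COc1cc2c(Oc3ccc(NC(=O)c4nnn(-c5ccccc5C(F)(F)F)c4C)cc3F)ccnc2cc1OCCCN1CCCC1` is the first of them. In a functional assay on A549 cells (Homo sapiens) for cytotoxicity, read by MTT assay, with a stated time of 72 h (a lower number here means a stronger inhibitor, a higher number a weaker inhibitor), compound 1 gives 160 nM. Compound 3 `COc1cc2c(Oc3ccc(NC(=O)c4nnn(-c5ccccc5C(F)(F)F)c4C)cc3F)ccnc2cc1OCCCN1CCCCC1` differs from compound 1 in one place only: piperidin-1-yl in place of pyrrolidin-1-yl on a saturated chain carbon, three bonds along the chain from an oxygen on an aromatic ring That change produced a 1.1-fold higher number from compound 1 to compound 3 (0.03 log units; within the scatter), so the two values sit together.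

Compound 2 `COc1cc2c(Oc3ccc(NC(=O)c4nnn(-c5ccc(F)cc5)c4C(F)(F)F)cc3F)ccnc2cc1OCCCN1CCCC1` belongs to the same family but differs from compound 1 in more than one place; the difference between the two cores is not broken down here. In this assay compound 2 gives 80 nM, while compound 3 gives 170 nM.

Compound 4 `COc1cc2c(Oc3ccc(NC(=O)c4nnn(-c5ccc(F)cc5)c4C(F)(F)F)cc3F)ccnc2cc1OCCCN1CCCCC1` has not yet been measured. It stands to compound 2 as compound 3 stands to compound 1: piperidin-1-yl in place of pyrrolidin-1-yl on a saturated chain carbon, three bonds along the chain from an oxygen on an aromatic ring The place of the change is the same in both pairs, so this is the same change carried out on a second core.

The expectation for compound 4 rests on that single earlier instance. Because a 1.1-fold higher number from compound 1 to compound 3 (0.03 log units; within the scatter) lay within the scatter, a similarly small shift is expected when the piperidin-1-yl ring replaces the pyrrolidin-1-yl ring on the core of compound 2. The expected step is a 1.1-fold higher number from compound 2 to compound 4 (0.05 log units; within the scatter). Compound 4 is therefore estimated at 90 nM, with a likely range from 45 nM to 180 nM.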

Compound 4, half-maximal inhibitory concentration: 110 nM
For compound 4 the middle estimate is 1.2-fold (0.09 log units) below the measured one; low and high end bracket the measured number.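

On the second core the swap again made little difference: in this assay, replacing pyrrolidin-1-yl with piperidin-1-yl at the end of the chain gave a 1.4-fold higher number from compound 2 to compound 4 (0.14 log units; within the scatter), so the two values sit together. Set side by side, the two instances of this change agree, and the core that carries it does not visibly alter the outcome: the same change on two cores in this assay, a 1.1-fold higher number (0.03 log units; within the scatter) from compound 1 to compound 3 and a 1.4-fold higher number (0.14 log units; within the scatter) from compound 2 to compound 4, 1.3-fold (0.11 log units) apart, within the scatter of two such steps This shows that, on these two cores and in this one cell assay, the ring at the chain end can be five- or six-membered with no step beyond the usual scatter, but two pairs cannot establish a rule for the whole series, and they do not explain why the swap matters so little.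

What the compounds shown leave open is how far this tolerance reaches, since every one of them ends in one of just these two saturated rings on the same chain. A morpholin-4-yl ring, an open-chain amine such as dimethylamino, or a shorter or longer chain might sit with these values or might move well away from them.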